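This account rests on a few compounds, and the source may have more. Where it says the series, first, only, none or still open, it means among the compounds named here.

Measured compounds in an assay on CHO cells for displacement of a labelled ligand from histamine receptor H3 (Macaca mulatta); on this read-out higher numbers stand for weaker inhibition and lower numbers for stronger inhibition:
compound 1, `CC1CCCN1C1CCN(c2ccc(NC(=O)CC3CCCC3)cc2)C1`: 3.1 nM
compound 2, `CC1CCCN1C1CCN(c2ccc(NC(=O)C3C(C)(C)C3(C)C)cc2)C1`: 144 nM
compound 3, `CC1CCCN1C1CCN(c2ccc(NC(=O)C3CC3)c(C(F)(F)F)c2)C1`: 14.7 nM

Compound 3 stands second highest of the three numbers in this assay: compound 1 gives a lower number and compound 2 a higher one, both differences beyond the scatter. Among the compounds with values here, the only single-point step among the measured compounds is a 46-fold higher number from compound 1 to compound 2 (1.67 log units; beyond the scatter), a change at the carbonyl substituent of the amide while the shared core is held.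

Compound 4, `Cc1cc(N2CCC(N3CCCC3C)C2)ccc1NC(=O)C1CC1`, differs from compound 3 in one place: methyl in place of trifluoromethyl on an aromatic carbon. Within the data shown here, no measured pair varies the substituent on this aromatic ring. The step from compound 1 to compound 2 concerns the amide side and does not bear on this change directly; it shows only that this assay can respond strongly to a single substitution in the series. Among the measured compounds shown here, for a change at the aromatic ring alone there is no measured precedent, so no step beyond the scatter is expected in either direction, and the range is set wide to cover an unknown response.

Compound 4 is therefore expected to give about 9 nM in this assay, between 3 nM and 30 nM. That estimate means an expected step of a 1.6-fold lower number from compound 3 to compound 4 (0.21 log units; within the scatter).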

Compound 4, inhibition constant: 9.6 nM
For compound 4 the middle estimate is 1.1-fold (0.03 log units) below the measured one; the measured number falls inside the stated range.
By their numbers in this assay, from the lowest: compound 1; then compounds 4 and 3 (each within the scatter of the next); then compound 2.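

In this assay, within the data shown here, methyl in place of trifluoromethyl on an aromatic carbon, ortho to a (cyclopropylcarbonyl)amino group, gives a 1.5-fold lower number from compound 3 to compound 4 (0.19 log units; within the scatter); this is the first measured pair that varies the substituent on this aromatic ring, and the exchange stays within the scatter. The group that leaves has 4 heavy atoms and the group that enters has 1, yet with the amide side held this difference brings no step beyond the scatter, in contrast to the change on the carbonyl carbon, a 46-fold higher number from compound 1 to compound 2 (1.67 log units; beyond the scatter). No measurement shown here gives a cause for this result.

The compounds shown leave open how this aromatic carbon responds to chlorine, a methoxy group, a nitrile or plain hydrogen, and whether a longer chain such as ethyl also stays within the scatter of methyl. They also leave open whether methyl and trifluoromethyl remain interchangeable in this assay when the cyclopentylmethyl of compound 1 or the 2,2,3,3-tetramethylcyclopropyl of compound 2 stands on the carbonyl carbon.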